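The source may report more compounds than this note shows. Statements on the series, on what has been measured and on what is new or still open speak of the compounds shown alone.

In a functional assay on MKN-74 cells (Homo sapiens) for antiproliferative activity, with a stated time of 24 h (a lower number here means a stronger inhibitor, a higher number a weaker inhibitor), compound 2 (`NC(=O)c1c(NC(=O)c2ccccc2Cl)sc2c1CCN(Cc1ccccc1F)C2`) gives 12900 nM while compound 1 (`N#Cc1ccccc1CN1CCc2c(sc(NC(=O)c3ccccc3Cl)c2C(N)=O)C1`) gives 9500 nM and the two sit within the scatter of each other. Compound 3 (`NC(=O)c1c(NC(=O)c2ccccc2Cl)sc2c1CCN(Cc1cc(Cl)cc(Cl)c1)C2`) has 3,5-dichlorophenyl in place of 2-fluorophenyl on a saturated chain carbon bound to an amine nitrogen in a ring. Going by the values given here, the only measured step, fluoro in place of cyano on an aromatic carbon, was a 1.4-fold higher number from compound 1 to compound 2 (0.13 log units; within the scatter) and it stayed small, so no step beyond the scatter is expected in this assay here, although no measured compound carries two chlorines. The expected change is a 1.3-fold lower number from compound 2 to compound 3 (0.11 log units; within the scatter) and stays small. Compound 3 is estimated at 10000 nM (range 4000 nM to 25000 nM).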

Compound 3, half-maximal inhibitory concentration: 23700 nM
Compound 3: middle estimate off by 2.4-fold (0.37 log units), on the low side; low and high end bracket the measured number.
By their numbers in this assay, from the lowest: compounds 1, 2 and 3 (each within the scatter of the next, the first and the last beyond it).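

In this assay this position, the saturated chain carbon bound to the ring amine nitrogen, now shows its first step beyond the scatter, a 2.5-fold higher number from compound 1 to compound 3 (0.40 log units; beyond the scatter) and this is a modest one. The other step, a 1.8-fold higher number from compound 2 to compound 3 (0.26 log units; within the scatter) stays within the scatter, so 3,5-dichlorobenzyl is set apart from 2-cyanobenzyl but not from 2-fluorobenzyl. No evidence here explains this difference. The compounds shown leave open how a single chlorine, a longer chain, or an amine or carboxylic acid on the phenyl ring would change the number.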